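The compounds below may be only part of what the source reports. "The series", "measured", "known", "first", "only" and "open" are said of these compounds alone.

Working notes on the bis-aryl sulfonamide urea series, cytotoxicity.

In an ADME assay on HEK-293T cells (Homo sapiens) for cytotoxicity, read by CCK-8 assay, with a stated time of 48 h (on this read-out lower numbers stand for stronger inhibition and higher numbers for weaker inhibition), compound 3 `Cc1ccc(-c2ccsc2S(=O)(=O)NCCNC(=O)Nc2cc(Cl)cc(Cl)c2)c(Oc2ccc(O)c(O)c2)c1` gives 6700 nM and compound 1 `O=C(NCCNS(=O)(=O)c1sccc1-c1ccccc1Oc1ccc(O)c(O)c1)Nc1cc(Cl)cc(Cl)c1` gives 10700 nM. The change between them, (hydrogen in place of methyl on an aromatic carbon), moves the read-out by a 1.6-fold higher number from compound 3 to compound 1 (0.20 log units; within the scatter). Compound 2 `Cc1ccc(-c2ccsc2S(=O)(=O)NCCNC(=O)Nc2cc(C(F)(F)F)cc(C(F)(F)F)c2)c(Oc2ccc(O)c(O)c2)c1` reaches only a limit in this assay, > 20000 nM; this is the limit of > 20000 nM in this assay, at which 1 of the 3 values shown sits. The difference between the cores of compound 2 and compound 3 is not broken down here.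

Compound 4 `O=C(NCCNS(=O)(=O)c1sccc1-c1ccccc1Oc1ccc(O)c(O)c1)Nc1cc(C(F)(F)F)cc(C(F)(F)F)c1` is not yet measured. It differs from compound 2 by hydrogen in place of methyl on an aromatic carbon, the same change as from compound 3 to compound 1. A step that the limit leaves unreadable from compound 2 to compound 4 is expected, resting on the step of a 1.6-fold higher number from compound 3 to compound 1 (0.20 log units; within the scatter) seen between compound 3 and compound 1. Compound 4 is therefore expected to sit near 30000 nM in this assay, most likely again at the limit, with a range from 15000 nM to 60000 nM.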

Compound 4, half-maximal inhibitory concentration: 8900 nM
Beside the measured number, compound 4's estimate is 3.4-fold (0.53 log units) above it; the whole stated range lies above it.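

In this assay, hydrogen in place of methyl on an aromatic carbon gives an at least 2.2-fold lower number from compound 2 to compound 4 (0.35 log units; beyond the scatter), and this step does not match the one seen on the other core: the same change on two cores in this assay, a 1.6-fold higher number (0.20 log units; within the scatter) from compound 3 to compound 1 and an at least 2.2-fold lower number (0.35 log units; beyond the scatter) from compound 2 to compound 4, at least 3.5-fold (0.55 log units) apart, beyond the scatter of two such steps
Going by these compounds, compound 2 stands at a limit of the assay, > 20000 nM, so the true size of this step stays unknown. Among these compounds, with only two pairs, the result shows that this change does not carry over unaltered, but it gives no rule for other cores and no reason for the gap.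

Still open, on these data alone, is how the same change behaves with a longer chain in place of the ethylene linker. Also open, as far as these compounds go, is the effect of a carboxylic acid in place of the 3,4-dihydroxyphenoxy group.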